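The compounds below may be only part of what the source reports. "The series", "measured", "known", "first", "only" and "open" are said of these compounds alone.

Working notes on a small set of ureas built on one shared core.

Compound 1 `C[C@H](NC(=O)Nc1ccccc1F)c1ccccc1` gives 92% in an ADME assay on the whole organism with Oryza sativa as the target, tested at 1 uM; on this read-out higher numbers stand for a weaker effect at the one concentration tested and lower numbers for a stronger effect. Compound 2 `C[C@@H](NC(=O)Nc1ccc(F)cc1)c1ccccc1` gives 96% in this assay; the difference between the cores of compound 1 and compound 2 is not broken down here. Compound 3 `C[C@H](NC(=O)Nc1cccc(F)c1F)c1ccccc1` gives 100% in this assay. From compound 1 to compound 3 the change is fluoro in place of hydrogen on an aromatic carbon, and the step is a number 8 percentage points higher from compound 1 to compound 3 (within the scatter).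

Compound 4 `C[C@@H](NC(=O)Nc1ccc(F)cc1F)c1ccccc1`, not yet measured, carries the same kind of change from compound 2: fluoro in place of hydrogen on an aromatic carbon. The surroundings differ: in compound 3 the entering fluoro sits ortho to a fluoro group and meta to a large group, in compound 4 ortho to a large group and meta to a fluoro group.

Expected is a step of a number 3 percentage points higher from compound 2 to compound 4 (within the scatter), resting on compound 1, whose step was a number 8 percentage points higher from compound 1 to compound 3 (within the scatter). For compound 4 the estimate is 99%, within 90% to 106%.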

Compound 4, a percentage reported as activity, at one concentration (the size of the read-out at that concentration, not a potency): 100%
Beside the measured number, compound 4's estimate is 1 percentage points below it; low and high end bracket the measured number.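

Fluoro in place of hydrogen on an aromatic carbon, here ortho to a large group and meta to a fluoro group, gives a step of a number 4 percentage points higher from compound 2 to compound 4 (within the scatter) in this assay. Set beside the earlier step, the change carries from one core to the other without a difference that can be told apart: the same change on two cores in this assay, a number 8 percentage points higher (within the scatter) from compound 1 to compound 3 and a number 4 percentage points higher (within the scatter) from compound 2 to compound 4, 4 percentage points apart, within the scatter of two such steps

Among the compounds shown here, this shows only that the step stays within the scatter on both cores; it does not show that fluoro has any effect of its own on this read-out, nor how it would behave on other cores.

The only aromatic substituent among the compounds shown is fluoro. On these data alone, what a chloro, methoxy or amine group on that ring would do in this assay, or a longer chain in place of the methyl group, remains open.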